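Adding a Methyl Group to Compound 2: What to Expect

A few compounds are considered here, and "the series" means these few. Any claim that something is new, unique, unknown or untested is made for them only; others in the source may bear on it.

Measured so far:
Compound 1 `S=C(Nc1ccccc1)Nc1ccc2[nH]ccc2c1` gives 57500 nM in an ADME assay on cells for inhibition of Amine oxidase [flavin-containing] A (Homo sapiens), read by spectrophotometry; a higher number here means a weaker inhibitor, a lower number a stronger inhibitor.
Compound 2 `Oc1ccccc1NC(=S)Nc1ccc2[nH]ccc2c1` gives 14000 nM in this assay.

For the measured compounds named here, compound 2 holds the lowest of the two numbers in this assay; the single measured step, a 4.1-fold lower number from compound 1 to compound 2 (0.61 log units; beyond the scatter), separates it from the other compound. Compound 3 `Cc1ccc(NC(=S)Nc2ccc3[nH]ccc3c2)c(O)c1` differs from compound 2 by methyl in place of hydrogen on an aromatic carbon. Going by the values given here, that one measured step concerned a hydroxy group, so no measured step bears directly on adding a methyl group. Compound 3 is therefore expected to stay close to compound 2, with a 1.2-fold lower number from compound 2 to compound 3 (0.07 log units; within the scatter) expected to lie within the scatter. The estimate for compound 3 is 12000 nM, with a range from 4000 nM to 35000 nM.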

Compound 3, half-maximal inhibitory concentration: 24000 nM
Estimate against measurement, compound 3: 2.0-fold (0.30 log units) below; the measured number falls inside the stated range.
By their numbers in this assay, from the lowest: compounds 2 and 3 (each within the scatter of the next); then compound 1.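

With a 1.7-fold higher number from compound 2 to compound 3 (0.23 log units; within the scatter) in this assay, methyl on this aromatic carbon, para to a large group and meta to a hydroxy group, gives no change that can be told apart from repeat measurements. The earlier step showed that a hydroxy group on the aromatic ring could shift the number; this one shows that the position para to a large group accepts one added carbon. No supporting data on the cause bear on this result. Still open, from the compounds shown here alone, is whether a longer chain, such as ethyl, or an amine at this position would leave the number as little moved. Also open, going by these compounds, is whether methyl would behave the same without the hydroxy group.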